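Working notes on the shared core series toward compound 4

A few compounds are considered here, and "the series" means these few. Any claim that something is new, unique, unknown or untested is made for them only; others in the source may bear on it.

Measured so far:
Compound 1 `CCCCCCCCc1cn(C(c2ccccc2)c2cc3cc(Br)ccc3nc2OC)nn1` in an ADME assay on HEK293 cells (Homo sapiens) for cytotoxicity, read by sulforhodamine B assay, with a stated time of 48 h, tested at 10 uM (a lower number here means less inhibition, a higher number more inhibition at the concentration tested (going by the name of the read-out)), gives 14.6%.
Compound 2 `COc1nc2ccc(Br)cc2cc1C(c1ccccc1)n1cc(-c2ccc(OC(F)(F)F)cc2)nn1` in this assay gives 5.8%.
Compound 3 `COc1nc2ccc(Br)cc2cc1C(c1ccccc1)n1cc(CCO)nn1` in this assay gives 4.54%.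

Compound 3 holds the lowest of the three numbers; it lies within the scatter of compound 2 and beyond it only against compound 1, as a number 10.1 percentage points lower from compound 1 to compound 3 (beyond the scatter) shows. The next step is to compound 4 `COc1nc2ccc(Br)cc2cc1C(c1ccccc1)n1cc(C2CC2)nn1`: cyclopropyl in place of 2-hydroxyethyl on an aromatic carbon. Within the data shown here, two measured steps bear on this position: a number 10.1 percentage points lower from compound 1 to compound 3 (beyond the scatter), a modest drop, and a number 1.3 percentage points lower from compound 2 to compound 3 (within the scatter), within the scatter. Cyclopropyl, three carbon atoms in one ring, sits between these cases, so a step no larger than the scatter is expected, a number 3.5 percentage points higher from compound 3 to compound 4 (within the scatter). Compound 4 is estimated at 8%, with a range from 0% to 18%.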

Compound 4, a percentage reported as inhibition, at one concentration (the size of the read-out at that concentration, not a potency): 8.22%
The estimate for compound 4 lay 0.2 percentage points below the measured number, and the stated range covers the measured number.
By their numbers in this assay, from the lowest: compounds 3, 2, 4 and 1 (each within the scatter of the next, the first and the last beyond it).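

In this assay, cyclopropyl in place of 2-hydroxyethyl gives up the hydrogen-bond donor and acceptor and adds a ring at the same heavy-atom count, yet the step stays within the scatter (a number 3.7 percentage points higher from compound 3 to compound 4 (within the scatter)). Compound 4 also lies within the scatter of both other groups at this position (a number 2.4 percentage points higher from compound 2 to compound 4 (within the scatter) and a number 6.4 percentage points lower from compound 1 to compound 4 (within the scatter)), so it separates from none of the three, even though compound 1 and compound 3 stand apart. No evidence on the series bears on this result.

From the compounds shown here alone, what an amine or a carboxylic acid would give on this aromatic carbon remains open.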